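A few compounds are considered here, and "the series" means these few. Any claim that something is new, unique, unknown or untested is made for them only; others in the source may bear on it.

Measured compounds, paw-edema inhibition in a functional assay on the whole organism (strain albino) for inhibition, with Rattus norvegicus as the target, read by paw edema, with a stated time of 4 h, at a dose of 0.029 mmol/kg by the oral route; on this read-out higher numbers stand for more inhibition at the one dose given (going by the name of the read-out) and lower numbers for less inhibition:
- compound 1 `CCCC/N=c1/c(C#N)c2n(c(=O)n1-c1ccccc1)CCC2`: 22.4%
- compound 2 `N#CC1=C(NCCN)N(c2ccccc2)C(=O)N2CCCC12`: 16.9%
- compound 3 `NC1=C(/C(N)=N\O)C2CCCN2C(=O)N1c1ccccc1`: 27.3%

Within this set compound 3 carries the highest of the three numbers. Its gap to compound 1 falls within the usual scatter of this kind of measurement, so no order between the two can be claimed; its gap to compound 2 lies beyond the scatter. Within the data shown here, no pair of the three differs in a single place, so none of these gaps can be tied to one structural change.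

The step from compound 3 to compound 4 `N/N=C(/N)C1=C(N)N(c2ccccc2)C(=O)N2CCCC12` is a single change: amino in place of hydroxy on a double-bonded nitrogen. The heavy-atom count, the ring count and the donor and acceptor counts are unchanged, and nothing in the measured set shows what an amino in place of hydroxy on a double-bonded nitrogen does in this assay. Among the measured compounds shown here, with no comparable step on record, the expectation is that compound 4 stays close to compound 3, with any step in this assay more likely small than large and of no certain direction.

Compound 4 is therefore estimated at 25%, in the range 12% to 38%.

The expected change is a number 2.3 percentage points lower from compound 3 to compound 4 (within the scatter), a step estimated to lie within the scatter.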

Compound 4, a percentage reported as inhibition, in the whole organism at one dose (the size of the read-out at that dose, not a potency): 23%
Beside the measured number, compound 4's estimate is 2 percentage points above it; low and high end bracket the measured number.
By their numbers in this assay, from the lowest: compounds 2, 1, 4 and 3 (each within the scatter of the next, the first and the last beyond it).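

In this assay, among these compounds, the exchange of hydroxy for amino gives the first single-place comparison: a number 4.3 percentage points lower from compound 3 to compound 4 (within the scatter) is a step that stays within the scatter, so no direction can be claimed for it. At this place, on a double-bonded nitrogen whose other neighbours are carbon with a double bond to nitrogen, the read-out at this one dose and time does not tell amino from hydroxy, so either group serves equally well as a starting point for further comparison there. No measurement at hand bears on why this step has the size it has.

As far as these compounds go, what a methoxy group or a plain hydrogen on that same nitrogen would do in this assay stays open, as does whether a larger group such as benzyloxy would move the number beyond the scatter. Compound 1 and compound 2 carry neither hydroxy nor amino on a double-bonded nitrogen of this kind, so they cannot show whether the exchange would read the same way on a different substitution of the shared core.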